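This account rests on a few compounds, and the source may have more. Where it says the series, first, only, none or still open, it means among the compounds named here.

Working notes on the dithiocarbamate series.

Three compounds share the core of compound 1 `Nc1ccccc1NC(=O)c1ccc(CSC(=S)N2CCN(Cc3ccccn3)CC2)cc1` and have been tested in a functional assay on MGC-803 cells (Homo sapiens) for antiproliferative activity, read by CCK-8 assay, with a stated time of 72 h, tested at 8 uM (a higher number here means a stronger effect of the compound at the concentration tested, a lower number a weaker effect), where compound 1 gives 65.2%. Compound 3 `Nc1ccccc1NC(=O)c1ccc(CSC(=S)N2CCN(c3cccnc3)CC2)cc1` gives 76.9% in this assay, and the change from compound 1 to compound 3, pyridin-3-yl in place of (pyridin-2-yl)methyl on an amine nitrogen in a ring, shows a number 11.7 percentage points higher from compound 1 to compound 3 (beyond the scatter). Compound 2 `CN(Cc1cccnc1)C(=S)SCc1ccc(C(=O)Nc2ccccc2N)cc1` gives 85.5% in this assay. Compound 2 stands above compound 1 beyond the scatter; compound 2 and compound 3 lie within the scatter of each other.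

Compound 4 `Nc1ccccc1NC(=O)c1ccc(CSC(=S)N2CCCC2)cc1` has not yet been measured. Compared with compound 2 the change is pyrrolidin-1-yl in place of methyl((pyridin-3-yl)methyl)amino on a thiocarbonyl carbon. Among the measured compounds shown here, no measured step touches this kind of change: the only step known, from compound 1 to compound 3, alters the substituent on an amine nitrogen in a ring and keeps the ring on the thiocarbonyl carbon, so it gives no direct guide here. Without a bearing step, the expected step from compound 2 to compound 4 is a number 15.5 percentage points lower from compound 2 to compound 4 (beyond the scatter), a modest drop carrying wide uncertainty. Compound 4 is therefore expected to give 70% in this assay, within a range from 50% to 88%.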

Compound 4, a percentage reported as inhibition, at one concentration (the size of the read-out at that concentration, not a potency): 83.4%
For compound 4 the middle estimate is 13.4 percentage points below the measured one; measured number inside the range.
By their numbers in this assay, from the lowest: compound 1; then compounds 3, 4 and 2 (each within the scatter of the next).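

On the thiocarbonyl carbon, pyrrolidin-1-yl in place of methyl((pyridin-3-yl)methyl)amino gives a number 2.1 percentage points lower from compound 2 to compound 4 (within the scatter) in this assay. This position therefore tolerates the loss of the six-membered aromatic ring in this pair, with a smaller non-aromatic ring keeping the read-out at the concentration tested. Among the compounds shown, compound 4 alone has no aromatic ring in the group on this carbon, whereas the earlier compounds left this question untouched.

Still open, as far as these compounds go, is whether other groups on this carbon, such as diethylamino or morpholin-4-yl, behave in the same way, and whether compound 2 and compound 4 would also match in potency, since a read-out at one concentration cannot show this. Nothing at hand accounts for the size of this step.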